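Fluoro on the sulfonyl aryl: compound 3 to compound 4

This account rests on a few compounds, and the source may have more. Where it says the series, first, only, none or still open, it means among the compounds named here.

Compound 3 `CC1=NC(c2cn(S(=O)(=O)c3ccccc3)c3ccc(C)cc23)CN1` holds the lowest of the two numbers measured in an assay on isolated protein for inhibition of kallikrein-7 (Homo sapiens), read by fluorescence, with stated times of 10 min and 30 min (a higher number here means a weaker inhibitor, a lower number a stronger inhibitor), where compound 3 gives 17000 nM. Compound 1 `Cc1ccc(S(=O)(=O)n2cc(C3CNC(C(C)C)=N3)c3ccccc32)cc1` gives 70000 nM in this assay. Compound 2 `Cc1ccc(S(=O)(=O)n2cc(C3CNC(C4CCCCC4)=N3)c3ccccc32)cc1` gives > 100000 nM in this assay, which is a limit of the assay and not a number (the limit of > 100000 nM in this assay, at which 1 of the 3 values shown sits). Among the measured compounds shown here, the one measured step, an at least 1.4-fold higher number from compound 1 to compound 2 (0.15 log units; that floor lies within the scatter), changes the group on a carbon with a double bond to nitrogen and so does not bear on the present change. Compound 4 `CC1=NC(c2cn(S(=O)(=O)c3ccc(F)cc3)c3ccc(C)cc23)CN1` differs from compound 3 by fluoro in place of hydrogen on an aromatic carbon, read one bond further out as phenyl to 4-fluorophenyl. For the measured compounds named here, no measured step touches that ring, so the step of a 1.1-fold lower number from compound 3 to compound 4 (0.05 log units; within the scatter) is expected to remain within the scatter. Compound 4 is estimated at 15000 nM, with a range from 6000 nM to 40000 nM.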

Compound 4, half-maximal inhibitory concentration: 9400 nM
Compound 4: middle estimate off by 1.6-fold (0.20 log units), on the high side; measured number inside the range.
By their numbers in this assay, from the lowest: compounds 4 and 3 (each within the scatter of the next); then compound 1. At a limit, above all of these: compound 2.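

Fluoro on this aromatic carbon, para to a large group, gives the first reading on the sulfonyl aryl ring. In this assay the change is a 1.8-fold lower number from compound 3 to compound 4 (0.26 log units; within the scatter), so this position takes fluoro without a shift that can be told from the scatter. Nothing measured here gives a cause for this step.

From the compounds shown here alone, whether methoxy, an amine or a carboxylic acid on this carbon would move the number beyond the scatter stays open. So does whether fluoro gives the same step with isopropyl or cyclohexyl on the carbon with a double bond to nitrogen.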